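Removing a Methyl From the Aryl Oxygen

The source may hold more compounds than are shown below. What is called first, only, known or untested is meant among the compounds shown, and "the series" means these compounds.

Of the compounds shown here, two of a shared core have been tested in a functional assay on SF-295 cells (Homo sapiens) for inhibition, read by sulforhodamine B assay, with a stated time of 48 h; on this read-out higher numbers stand for weaker inhibition of growth and lower numbers for stronger inhibition of growth. Compound 1, with the structure `O=C(Nc1cccc(-n2cc(-c3ccncc3)c(-c3ccc(Cl)c(O)c3)n2)c1)Nc1cccc(C(F)(F)F)c1`, gives 962 nM. Compound 2, with the structure `COc1cc(-c2nn(-c3cccc(NC(=O)Nc4cc(C(F)(F)F)cc(C(F)(F)F)c4)c3)cc2-c2ccncc2)ccc1Cl`, gives 399 nM in this assay, the lower of the two numbers, with compound 1 standing a step above it that lies beyond the usual scatter.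

The next compound, compound 3, has the structure `O=C(Nc1cccc(-n2cc(-c3ccncc3)c(-c3ccc(Cl)c(O)c3)n2)c1)Nc1cc(C(F)(F)F)cc(C(F)(F)F)c1`. It differs from compound 2 in one place: hydrogen in place of methyl on an oxygen on an aromatic ring, so that the 4-chloro-3-methoxyphenyl group becomes a 4-chloro-3-hydroxyphenyl group, while the rest of the molecule is unchanged. For the measured compounds named here, no pair of measured compounds differs by this change alone, so the size of the step cannot be read from the data; compound 1 carries the hydroxy group but also a different urea end, so its value alone cannot separate the two changes.

The step from compound 2 to compound 3 is expected to be small, perhaps a modest weakening, at a 1.5-fold higher number from compound 2 to compound 3 (0.18 log units; within the scatter). For compound 3 the estimate in this assay is 600 nM, with a range from 250 nM to 1500 nM.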

Compound 3, concentration for 50% growth inhibition: 618 nM
Beside the measured number, compound 3's estimate is 1.0-fold (0.01 log units) below it; the measured number falls inside the stated range.
By their numbers in this assay, from the lowest: compounds 2, 3 and 1 (each within the scatter of the next, the first and the last beyond it).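

In this assay, the change from methyl to hydrogen on this aromatic oxygen can now be read on its own, with the urea end held fixed: it gives a 1.5-fold higher number from compound 2 to compound 3 (0.19 log units; within the scatter), so on this core the methoxy and hydroxy forms cannot be told apart by this read-out. For the compounds shown here, compound 3 also isolates the other difference carried by the earlier compounds, since adding a trifluoromethyl group on an aromatic carbon of the urea end, with the hydroxy group in place, gives a 1.6-fold lower number from compound 1 to compound 3 (0.19 log units; within the scatter), again a step that cannot be told from repeat-measurement noise. No supporting measurement is available to explain either step.

On these data alone, whether the oxygen would accept an ethyl group, a longer chain or a chain ending in an amine remains open, as does what would happen if an amine or a fluorine replaced the hydroxy group. Also open, as far as these compounds go, is whether the methyl-to-hydrogen step would stay this small on a urea end carrying something other than trifluoromethyl, such as a nitrile or a carboxylic acid.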